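Taking one methyl off compound 2

The source may hold more compounds than are shown below. What is called first, only, known or untested is meant among the compounds shown, and "the series" means these compounds.

Within the data shown here, in a functional assay on V79 cells (Cricetulus griseus) for cytotoxicity, read by colony formation (a higher number here means a weaker inhibitor, a lower number a stronger inhibitor), compound 2 `CC1CN(c2c(F)cc3c(=O)c(C(=O)O)cn(C4CC4)c3c2Cl)CC(C)N1` gives 140 ug/mL and holds the higher of the two numbers so far, while compound 1 `NCC1CCN(c2c(F)cc3c(=O)c(C(=O)O)cn(C4CC4)c3c2Cl)C1` gives 8 ug/mL on the same core. Compound 3 `CC1CN(c2c(F)cc3c(=O)c(C(=O)O)cn(C4CC4)c3c2Cl)CCN1` has not yet been measured. It differs from compound 2 by hydrogen in place of methyl on a saturated ring carbon and so carries hydrogen in place of methyl on a saturated ring carbon, which makes 3,5-dimethylpiperazin-1-yl into 3-methylpiperazin-1-yl. Among the measured compounds shown here, the only measured step is an 18-fold higher number from compound 1 to compound 2 (1.24 log units; beyond the scatter) and it is large, but it exchanges a whole group, 3,5-dimethylpiperazin-1-yl in place of 3-(aminomethyl)pyrrolidin-1-yl, so it offers only a loose guide to the loss of one methyl. A far smaller, downward move is therefore expected, and the estimated step is a 2.0-fold lower number from compound 2 to compound 3 (0.30 log units; within the scatter) in this assay at the edge of the scatter. Compound 3 is estimated at 70 ug/mL with a range of 25 ug/mL to 170 ug/mL on the evidence so far.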

Compound 3, half-maximal inhibitory concentration: 45 ug/mL
The estimate for compound 3 lay 1.6-fold (0.19 log units) above the measured number; the measured number falls inside the stated range.
By their numbers in this assay, from the lowest: compound 1; then compound 3; then compound 2.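

In this assay, the loss of a single methyl from a saturated ring carbon gives a 3.1-fold lower number from compound 2 to compound 3 (0.49 log units; beyond the scatter), so even this one-carbon change moves the number by more than the usual scatter. A clear gap to the 3-(aminomethyl)pyrrolidin-1-yl group remains, with a 5.6-fold higher number from compound 1 to compound 3 (0.75 log units; beyond the scatter), so taking off this methyl closes only part of the distance between compound 2 and compound 1. Nothing available explains why the number moves with this change.

On these data alone, it remains open whether a piperazin-1-yl group with no methyl at all would continue the downward move, and whether an ethyl or hydroxymethyl group on this ring carbon would shift the number in the same direction. The compounds shown also cannot tell whether the methyl step would be the same size on a different core.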